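This account rests on a few compounds, and the source may have more. Where it says the series, first, only, none or still open, it means among the compounds named here.

Compound 1 `COCCOCCOCCOC(=O)Oc1c(C(C)C)cccc1C(C)C`: 2130000 nM
Compound 2 `COCCOCCOCCOCCOC(=O)Oc1c(C(C)C)cccc1C(C)C`: 1360000 nM

Within the data shown here, in an ADME assay on A549 cells (Homo sapiens) for cytotoxicity, read by MTT assay, with a stated time of 24 h (a lower number here means that less compound is needed, a higher number that more compound is needed for the effect), compound 2 holds the lower of the two numbers so far, with compound 1 its only neighbour; the single measured step, a 1.6-fold lower number from compound 1 to compound 2 (0.19 log units; within the scatter), lies within the scatter. Compound 3 `COCCOCCOC(=O)Oc1c(C(C)C)cccc1C(C)C` has not yet been measured. It differs from compound 2 by hydrogen in place of (2-methoxyethoxy)methyl on a saturated chain carbon bound to an oxygen on a saturated carbon. Since that step only bears on this change and was itself within the scatter, compound 3 is expected to show no step beyond the scatter, at most a modest rise, a 1.8-fold higher number from compound 2 to compound 3 (0.26 log units; within the scatter). Compound 3 is therefore estimated at 2500000 nM, with a range from 1200000 nM to 5500000 nM.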

Compound 3, half-maximal effective concentration: > 10000000 nM
Compound 3: no number, only a limit; the forecaster's own chance of this, stated with the estimate: 10%; middle value at least 4.0-fold (0.60 log units) from the limit.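

In this assay, the chain carbon bound to an oxygen on a saturated carbon proves sensitive after all: hydrogen in place of (2-methoxyethoxy)methyl gives an at least 7.3-fold higher number from compound 2 to compound 3 (0.86 log units; beyond the scatter), and hydrogen in place of methoxymethyl gives an at least 4.6-fold higher number from compound 1 to compound 3 (0.67 log units; beyond the scatter). The earlier pair alone had shown no step beyond the scatter, so the shortest chain shown parts from the two longer ones. The reading for compound 3 is a limit, not a number: the limit of > 10000000 nM in this assay, at which 1 of the 3 values shown sits.

As far as these compounds go, the true size of both steps therefore stays open. So does the outcome for a longer chain than that of compound 2, or for an amine at the chain end.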